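A few compounds are considered here, and "the series" means these few. Any claim that something is new, unique, unknown or untested is made for them only; others in the source may bear on it.

Three compounds with the same core but different aryl groups on its saturated ring carbon have been tested in a functional assay (muscle tissue) with Cavia porcellus as the target; on this read-out higher numbers stand for an effect only at larger amounts of compound and lower numbers for an effect already at smaller amounts. Compound 1 `COC(=O)C1=C(C)N=C(C)/C(=C(\O)OC)C1c1c(Cl)cccc1Cl` gives 1.91 nM, compound 2 `C=Cc1ccccc1C1C(C(=O)OC)=C(C)N=C(C)/C1=C(\O)OC` gives 4.47 nM, and compound 3 `COC(=O)C1=C(C)N=C(C)/C(=C(\O)OC)C1c1cccc(I)c1` gives 41.7 nM. Compound 3 thus stands at the highest number of the three: a 22-fold higher number from compound 1 to compound 3 (1.34 log units; beyond the scatter) and a 9.3-fold higher number from compound 2 to compound 3 (0.97 log units; beyond the scatter), while a 2.3-fold higher number from compound 1 to compound 2 (0.37 log units; beyond the scatter). In each of these steps the whole aryl group was swapped.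

Compound 4 `COC(=O)C1=C(C)N=C(C)/C(=C(\O)OC)C1c1cccc(C)c1` differs from compound 3 in one place: methyl in place of iodo on an aromatic carbon. Going by the values given here, no measured step exchanges a single substituent on the aryl group; the two steps that end at compound 3 replace a different aryl group by 3-iodophenyl, and they say only that the 3-iodophenyl compound sits at the top of this small set. Nothing in the measured steps tells how iodo against methyl in the same position shifts the read-out. The expectation is therefore a step of no clear direction, most likely within or near the scatter, with a slight lean toward a lower number because compound 3 already holds the highest value, 41.7 nM, among the measured compounds. Compound 4 is estimated at 30 nM, in a range from 8 nM to 120 nM, which means an expected step of a 1.4-fold lower number from compound 3 to compound 4 (0.14 log units; within the scatter).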

Compound 4, half-maximal effective concentration: 110 nM
Compound 4: middle estimate off by 3.7-fold (0.56 log units), on the low side; the measured number falls inside the stated range.
By their numbers in this assay, from the lowest: compound 1; then compound 2; then compound 3; then compound 4.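

In this assay, going by these compounds alone, the exchange of iodo for methyl on an aromatic carbon, meta to a large group, gives a 2.6-fold higher number from compound 3 to compound 4 (0.42 log units; beyond the scatter) and is the first step here that changes a single substituent rather than the whole aryl group. It shows that this one place on the aryl ring matters on its own: one heavy atom replaced by one heavy atom, with no hydrogen-bond donor or acceptor on either side, still moves the number beyond the scatter. Whole-aryl swaps now give a 25-fold higher number from compound 2 to compound 4 (1.39 log units; beyond the scatter) and a 58-fold higher number from compound 1 to compound 4 (1.76 log units; beyond the scatter), so the 3-methylphenyl compound, not the 3-iodophenyl compound, sits at the end of the set where an effect appears only at larger amounts, and no measurement at hand explains this difference.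

Going by these compounds, only iodo and methyl can be compared at this place, so it stays open where an amine, a carboxylic acid or a longer chain would fall on this read-out. On these data alone, it also stays open whether iodo and methyl would differ by a similar step on other carbons of the aryl ring, or on an aryl group that carries further substituents.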